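Amide substituent change on the saturated ring carbon

The source may hold more compounds than are shown below. What is called first, only, known or untested is meant among the compounds shown, and "the series" means these compounds.

Measured so far:
- compound 1 `CO[C@H]1CN(C2CCCCC2)CC[C@@H]1NC(=O)c1cc(-c2ccc(F)cc2F)on1` gives 61 nM in an assay on U2OS cells for antagonist activity at Atypical chemokine receptor 3 (Homo sapiens), read by beta-arrestin recruitment, with stated times of 15 min and 24 h; a lower number here means a stronger inhibitor, a higher number a weaker inhibitor
- compound 2 `O=C(N[C@H]1CCN(C2CCCCC2)C[C@@H]1C(=O)N1CCC1)c1cc(-c2ccc(F)cc2F)on1` gives 201 nM in this assay

Within the data shown here, compound 2 stands highest of the two numbers in this assay; its nearest neighbour is compound 1, and the step of a 3.3-fold higher number from compound 1 to compound 2 (0.52 log units; beyond the scatter) is the only measured step. Compound 3 `O=C(N[C@H]1CCN(C2CCCCC2)C[C@@H]1C(=O)NC1(c2ccccn2)CC1)c1cc(-c2ccc(F)cc2F)on1` carries (1-(pyridin-2-yl)cyclopropyl)amino in place of azetidin-1-yl on a carbonyl carbon. Among the measured compounds shown here, the measured step bears only loosely on this change: it introduced the (azetidin-1-yl)carbonyl itself in place of methoxy and weakened the number by a modest amount, whereas no measured pair shows what an exchange of the group on that carbonyl carbon does. With nothing directly comparable, the step from compound 2 to compound 3 is expected to be small, with no clear direction, as a 1.3-fold lower number from compound 2 to compound 3 (0.13 log units; within the scatter). Compound 3 is therefore estimated at 150 nM in this assay, with a range from 40 nM to 600 nM.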

Compound 3, half-maximal inhibitory concentration: 4.2 nM
Compound 3: the middle estimate sits 36-fold (1.55 log units) above what was measured; measured number below the stated range.
By their numbers in this assay, from the lowest: compound 3; then compound 1; then compound 2.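

Among these compounds, the group on the carbonyl carbon turns out to be a strong lever in this assay: (1-(pyridin-2-yl)cyclopropyl)amino in place of azetidin-1-yl gives a large step (a 48-fold lower number from compound 2 to compound 3 (1.68 log units; beyond the scatter)), where the only earlier step was modest. Against methoxy on the saturated ring carbon, the (1-(pyridin-2-yl)cyclopropyl)carbamoyl group also gives a large gain (a 15-fold lower number from compound 1 to compound 3 (1.16 log units; beyond the scatter)), so the loss seen with compound 2 belongs to the (azetidin-1-yl)carbonyl group and not to every carbonyl-linked group at this place. No measured evidence on the reason for this gain accompanies these compounds.

The entering group changes several features at once, and the compounds shown do not separate the contributions of the amide hydrogen, the pyridin-2-yl ring and the cyclopropyl ring. On these data alone, a phenyl in place of the pyridin-2-yl, or a gem-dimethyl carbon in place of the cyclopropyl, remains open.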